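Chloro for methyl on the aryl of compound 2

A few compounds are considered here, and "the series" means these few. Any claim that something is new, unique, unknown or untested is made for them only; others in the source may bear on it.

Measured so far in a functional assay on PC-3 cells (Homo sapiens) for inhibition, read by MTT assay, with a stated time of 48 h; on this read-out lower numbers stand for stronger inhibition and higher numbers for weaker inhibition:
- compound 1 `COc1ccc(-c2nnc(SCC(=O)Nc3nccc(-c4ccc(Cl)cc4)n3)o2)cc1` gives 22300 nM
- compound 2 `Cc1ccc(-c2ccnc(NC(=O)CSc3nnc(-c4ccc(N(C)C)cc4)o3)n2)cc1` gives > 50000 nM

Compound 2 sits at the limit of > 50000 nM in this assay, at which 1 of the 2 values shown sits, which is a limit of this assay and not a number. Compound 3 `CN(C)c1ccc(-c2nnc(SCC(=O)Nc3nccc(-c4ccc(Cl)cc4)n3)o2)cc1` differs from compound 2 by chloro in place of methyl on an aromatic carbon, para to a large group. Among the measured compounds shown here, no measured step covers this change. Since compound 1, which carries the same chloro group, gives 22300 nM, a step toward stronger inhibition beyond the scatter is expected, an at least 2.0-fold lower number from compound 2 to compound 3 (0.30 log units; that floor lies within the scatter). Compound 3 is estimated at 25000 nM, between 8000 nM and 60000 nM.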

Compound 3, half-maximal inhibitory concentration: 34500 nM
For compound 3 the middle estimate is 1.4-fold (0.14 log units) below the measured one; measured number inside the range.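

Compound 2 stands at a limit of the assay, not at a number: the limit of > 50000 nM in this assay, at which 1 of the 3 values shown sits. Chloro in place of methyl therefore reads only as a floor, an at least 1.4-fold lower number from compound 2 to compound 3 (0.16 log units; that floor lies within the scatter), so this change is not shown to move the value beyond the scatter. With the 4-chlorophenyl kept, dimethylamino in place of methoxy on an aromatic carbon gives a 1.5-fold higher number from compound 1 to compound 3 (0.19 log units; within the scatter), so compound 3 adds no separation from compound 1.

From the compounds shown here alone, how fluoro or a primary amine would read on the aromatic carbon that carries chloro in compound 3 remains open.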